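The compounds below may be only part of what the source reports. "The series", "measured", "known", "first", "only" and "open" are said of these compounds alone.

Measured in an ADME assay on HEL cells (Homo sapiens) for cytotoxicity; a lower number here means that less compound is tolerated, a higher number that more compound is tolerated:
- compound 1 `O=C(COc1cccc2ccccc12)N/N=C/c1ccccc1O` gives 3.57 ug/mL
- compound 2 `O=C(COc1cccc2ccccc12)N/N=C/c1c(O)ccc2ccccc12` gives 1.94 ug/mL
- compound 3 `O=C(COc1cccc2ccccc12)N/N=C/c1ccccc1[N+](=O)[O-]` gives 100 ug/mL

Compound 1 and compound 2 lie within the usual scatter of each other, so compound 1 sits in the low pair of these three, with compound 3 far above it. Compound 4 `O=C(COc1cccc2ccccc12)N/N=C/c1cccc(Cl)c1` has not yet been measured. The change from compound 1 is 3-chlorophenyl in place of 2-hydroxyphenyl on a carbon with a double bond to nitrogen and it puts 3-chlorophenyl in place of 2-hydroxyphenyl on a carbon with a double bond to nitrogen.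

For the measured compounds named here, the one measured step that bears on this is large: a 28-fold higher number from compound 1 to compound 3 (1.45 log units; beyond the scatter), with nitro in place of hydroxy on an aromatic carbon. Compound 4 also has no hydroxy, which points to a higher number in this assay. However, 3-chlorophenyl differs from the group in compound 3, and a single step is thin evidence, so a smaller rise is expected. The estimated step is a 5.6-fold higher number from compound 1 to compound 4 (0.75 log units; beyond the scatter). For compound 4 the expected value is 20 ug/mL, with an estimated range of 5 ug/mL to 100 ug/mL.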

Compound 4, half-maximal cytotoxic concentration: 58.6 ug/mL
For compound 4 the middle estimate is 2.9-fold (0.47 log units) below the measured one, and the stated range covers the measured number.
By their numbers in this assay, from the lowest: compounds 2 and 1 (each within the scatter of the next); then compounds 4 and 3 (each within the scatter of the next).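

In this assay, 3-chlorophenyl in place of 2-hydroxyphenyl on a carbon with a double bond to nitrogen gives a 16-fold higher number from compound 1 to compound 4 (1.22 log units; beyond the scatter), so a large rise at this place does not require the nitro group of compound 3. Compound 4 at 58.6 ug/mL and compound 3 at 100 ug/mL lie within the usual scatter of each other, and among the four compounds shown only compound 1 and compound 2 carry a hydroxy group and sit low, with none going against this pattern. No measurement here gives a reason for the rise.

As far as these compounds go, compound 4 loses the hydroxy group and gains the chlorine in a single change, so the effect of each alone stays unknown. Plain phenyl, 3-hydroxyphenyl or 2-methoxyphenyl at this place would help to separate the two.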